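The source may report more compounds than this note shows. Statements on the series, on what has been measured and on what is new or still open speak of the compounds shown alone.

Three compounds that share one core and differ only in the aromatic group on a carbon with a double bond to nitrogen have been measured in a functional assay on cells (Homo sapiens) for cytotoxicity, read by MTT assay, with a stated time of 24 h; on this read-out higher numbers stand for weaker inhibition and lower numbers for stronger inhibition. Compound 1 (`CCCCCCCCCCCCCCNC(=O)[C@H](CO)/N=C/c1ccc(OC)cc1`) gives 28100 nM, compound 2 (`CCCCCCCCCCCCCCNC(=O)[C@H](CO)/N=C/c1ccccc1OC`) gives 12500 nM, and compound 3 (`CCCCCCCCCCCCCCNC(=O)[C@H](CO)/N=C/c1ccccc1O`) gives 19000 nM. Compound 3 lies within the scatter of both others, with a 1.5-fold lower number from compound 1 to compound 3 (0.17 log units; within the scatter) and a 1.5-fold higher number from compound 2 to compound 3 (0.18 log units; within the scatter). Among the compounds with values here, only one measured step goes beyond the scatter, and it is modest: a 2.2-fold lower number from compound 1 to compound 2 (0.35 log units; beyond the scatter).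

Compound 4 (`CCCCCCCCCCCCCCNC(=O)[C@H](CO)/N=C/c1ccc([N+](=O)[O-])cc1`) changes the same place, with 4-nitrophenyl in place of 2-hydroxyphenyl on a carbon with a double bond to nitrogen. Within the data shown here, no measured compound carries 4-nitrophenyl, so the three steps bear on this change only indirectly, as exchanges of the aromatic group at this place. Among them, the exchange from compound 1 to compound 2 is the largest, at a 2.2-fold lower number from compound 1 to compound 2 (0.35 log units; beyond the scatter). On that evidence, no step beyond the scatter is expected in this assay, and the expected change is a 1.1-fold higher number from compound 3 to compound 4 (0.02 log units; within the scatter). For compound 4 the estimated value is 20000 nM, with an expected range from 9000 nM to 40000 nM.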

Compound 4, half-maximal inhibitory concentration: 217000 nM
Beside the measured number, compound 4's estimate is 11-fold (1.04 log units) below it; the measured number lies above the stated range.
By their numbers in this assay, from the lowest: compounds 2, 3 and 1 (each within the scatter of the next, the first and the last beyond it); then compound 4.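

Compound 4 shows that this place, on a carbon with a double bond to nitrogen, is far from indifferent to the aromatic group. In this assay the three earlier groups stayed close together, whereas 4-nitrophenyl gives an 11-fold higher number from compound 3 to compound 4 (1.06 log units; beyond the scatter) and a 17-fold higher number from compound 2 to compound 4 (1.24 log units; beyond the scatter), which makes compound 4 the weakest of the four, and even the exchange that changes only the group on the ring, nitro in place of methoxy, gives a 7.7-fold higher number from compound 1 to compound 4 (0.89 log units; beyond the scatter). Nothing available on these compounds accounts for this rise.

The compounds shown leave open whether the loss belongs to the nitro group itself or would also appear with another group in its place, such as an amine, a carboxylic acid, a chlorine atom or a nitrile on the same ring. They also leave open how an unsubstituted phenyl would stand against these four, and whether the same exchange would weigh as heavily with a longer chain on the shared core.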